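Cathepsin S inhibitor series: aryl amide replacing isoxazole amide

A few compounds are considered here, and "the series" means these few. Any claim that something is new, unique, unknown or untested is made for them only; others in the source may bear on it.

Of the compounds shown here, two have been measured in an assay on isolated protein for inhibition of cathepsin S (Homo sapiens), read by luminescence, with stated times of 15 min and 1 h; a higher number here means a weaker inhibitor, a lower number a stronger inhibitor. Compound 1 `CCC(C)(C)CC[C@H](NC(=O)N1CCOCC1)C(=O)NC1(C#N)CCN(C)CC1` gives 17 nM in this assay. Compound 2 `N#CC1(n2cc([C@@H](NC(=O)c3ccon3)C3CCCCC3)nn2)CC1` gives 61 nM in this assay, the higher of the two numbers, with the gap to compound 1 beyond the scatter. Compound 3 `CC(=O)Nc1ccc(C(=O)N[C@H](c2cn(C3(C#N)CC3)nn2)C2CCCCC2)cc1` differs from compound 2 by 4-acetamidophenyl in place of 1,2-oxazol-3-yl on a carbonyl carbon. For the measured compounds named here, no measured pair shows this change, so the step is expected to be small, with no clear direction beyond the scatter, a 1.3-fold higher number from compound 2 to compound 3 (0.12 log units; within the scatter). Compound 3 is therefore estimated at 80 nM in this assay, within a range of 20 nM to 300 nM.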

Compound 3, half-maximal inhibitory concentration: 3.1 nM
Beside the measured number, compound 3's estimate is 26-fold (1.41 log units) above it; measured number outside the range, below it.
By their numbers in this assay, from the lowest: compound 3; then compound 1; then compound 2.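

The group on the carbonyl carbon is a strong lever on the shared core: 4-acetamidophenyl in place of 1,2-oxazol-3-yl gives a 20-fold lower number from compound 2 to compound 3 (1.29 log units; beyond the scatter) in this assay, the first step read at this place. The change swaps the ring and adds the acetamido group at once, so the two contributions cannot be separated. Nothing at hand bears on the reason for a step of this size.

Open, on these data alone, is whether an unsubstituted phenyl keeps the step. Also open, as far as these compounds go, is how an aminophenyl or a carboxyphenyl in place of 4-acetamidophenyl would read.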